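Aryl variation on the shared core, step toward compound 4

The source may report more compounds than this note shows. Statements on the series, on what has been measured and on what is new or still open speak of the compounds shown alone.

Values in a functional assay on MCF7 cells (Homo sapiens) for inhibition, read by MTT assay, with a stated time of 24 h; on this read-out higher numbers stand for weaker inhibition and lower numbers for stronger inhibition:
compound 1 `Cc1ccc(-c2cc(COC3(C(F)(F)F)Oc4ccccc4C=C3C(=O)O)on2)cc1` gives 30100 nM
compound 2 `O=C(O)C1=Cc2ccccc2OC1(OCc1cc(-c2ccc([N+](=O)[O-])cc2)no1)C(F)(F)F` gives > 150000 nM, a limit of the assay
compound 3 `O=C(O)C1=Cc2ccccc2OC1(OCc1cc(-c2ccc3ccccc3c2)no1)C(F)(F)F` gives > 150000 nM, a limit of the assay

Compound 3 stands at the limit of the assay, and that limit is shared: the limit of > 150000 nM in this assay, at which 2 of the 3 values shown sit. Among the measured compounds shown here, the only numbered value belongs to compound 1, which carries 4-methylphenyl on the five-membered ring.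

Compound 4 `COc1ccc(-c2cc(COC3(C(F)(F)F)Oc4ccccc4C=C3C(=O)O)on2)cc1` differs from compound 3 by 4-methoxyphenyl in place of naphthalen-2-yl on an aromatic carbon. For the measured compounds named here, no measured step covers exactly this exchange, but two bear on it. Going the other way, from a single six-membered ring to the fused pair, the number rose: an at least 4.9-fold higher number from compound 1 to compound 3 (0.69 log units; beyond the scatter). Replacing methyl by nitro on that single ring also raised it: an at least 4.9-fold higher number from compound 1 to compound 2 (0.69 log units; beyond the scatter). The step between the two limits is not readable: a step that the two limits leave unreadable from compound 2 to compound 3.

Compound 4 returns to a single six-membered ring, as in compound 1, with a methoxy in place of the methyl. The expectation is therefore that compound 4 lands close to compound 1 rather than at the limit, estimated at 40000 nM (range 10000 nM to 150000 nM). Against compound 3 this means an expected drop in the number, an at least 3.7-fold lower number from compound 3 to compound 4 (0.57 log units; beyond the scatter), though its true size cannot be fixed from a starting limit, and a second limit for compound 4 remains possible.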

Compound 4, half-maximal inhibitory concentration: 35200 nM
Compound 4: middle estimate off by 1.1-fold (0.06 log units), on the high side; low and high end bracket the measured number.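

In this assay, the place on the five-membered ring next to the ring nitrogen now has a second single-ring group with a numbered value, and methoxy and methyl cannot be told apart there: a 1.2-fold higher number from compound 1 to compound 4 (0.07 log units; within the scatter). The readable value also holds against both of the other groups, with an at least 4.2-fold lower number from compound 3 to compound 4 (0.62 log units; beyond the scatter) for the exchange of the naphthalen-2-yl and an at least 4.2-fold lower number from compound 2 to compound 4 (0.62 log units; beyond the scatter) for methoxy in place of nitro, and both steps start from a limit of the assay, so their true size stays unfixed. A single six-membered ring at this place is therefore not enough for a numbered value, since the 4-nitrophenyl group of compound 2 stays at the limit along with the naphthalen-2-yl group of compound 3: the limit of > 150000 nM in this assay, at which 2 of the 4 values shown sit.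

Still open, on these data alone, is how an amine, a chlorine or a longer alkoxy chain in place of the methyl on the single ring would read on this scale. With only two numbered values in the series, both within the scatter of each other, the compounds shown also leave open whether any group at this place moves the number below that level.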